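A few compounds are considered here, and "the series" means these few. Any claim that something is new, unique, unknown or untested is made for them only; others in the source may bear on it.

Compound 1 `COc1cc(-c2nn(-c3cccc(NC(=O)Nc4cc(C(F)(F)F)cc(C(F)(F)F)c4)c3)cc2-c2ccncc2)ccc1Cl` was tested in a functional assay on T47D cells (Homo sapiens) for inhibition, read by sulforhodamine B assay, with a stated time of 48 h; on this read-out higher numbers stand for lower toxicity in this test and lower numbers for higher toxicity in this test. In this assay compound 1 gives only a limit of the assay, > 50000 nM, and not a number. Compound 2 `O=C(Nc1cccc(-n2cc(-c3ccncc3)c(-c3ccc(Cl)c(O)c3)n2)c1)Nc1ccc(Cl)c(Cl)c1` likewise gives only a limit in this assay, > 32500 nM. Both values therefore stand at limits, as shown by the limit of > 32500 nM in this assay, at which 1 of the 2 values shown sits, and (the limit of > 50000 nM in this assay, at which 1 of the 2 values shown sits), and neither compound shows toxicity within the tested range. Compound 3 `COc1cc(-c2nn(-c3cccc(NC(=O)Nc4cccc(C(F)(F)F)c4)c3)cc2-c2ccncc2)ccc1Cl` differs from compound 1 by hydrogen in place of trifluoromethyl on an aromatic carbon. The expected step is a number no higher from compound 1 to compound 3 (the limit leaves the size open), none beyond the scatter. Compound 3 is expected to give 50000 nM, in a range from 20000 nM to 100000 nM.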

Compound 3, concentration lethal to 50% of the cells: 50000 nM
Compound 3: the middle estimate sits on the measured number at the digits printed; measured number inside the range.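

In this assay compound 3 gives 50000 nM, the only actual number among the three compounds shown. Compound 1 gives > 50000 nM, which is a limit. With one trifluoromethyl replaced by hydrogen and the other kept on the ring, the result is a number no higher from compound 1 to compound 3 (the limit leaves the size open), so a value can now be read, but the size of the change cannot.

Going by these compounds, it remains open whether another group at this place, such as an amine or a carboxylic acid, would give a clearly lower number in this assay.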